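From Benzyloxy to Ethoxy: Testing a Smaller Group

The compounds below may be only part of what the source reports. "The series", "measured", "known", "first", "only" and "open" are said of these compounds alone.

Measured so far in a functional assay on HCT-116 cells (Homo sapiens) for antiproliferative activity; a higher number here means a weaker inhibitor, a lower number a stronger inhibitor
- compound 1 `Cc1cc2c(F)c(Oc3ncnc(N)c3/C=N/OCc3ccccc3)ccc2[nH]1` gives 311 nM
- compound 2 `CO/N=C/c1c(N)ncnc1Oc1ccc2ncccc2c1` gives 2870 nM

Compound 1 has the lower of these two numbers, and its gap to compound 2 lies beyond the scatter. Compound 3 `CCO/N=C/c1c(N)ncnc1Oc1ccc2[nH]c(C)cc2c1F` keeps the core of compound 1 but has methyl in place of phenyl on a saturated chain carbon bound to an oxygen, turning benzyloxy into ethoxy. Among the measured compounds shown here, no measured pair isolates this change, so any forecast is uncertain. A moderate weakening, slightly beyond the scatter, is expected (a 2.6-fold higher number from compound 1 to compound 3 (0.41 log units; beyond the scatter)). Compound 3 is estimated at 800 nM (expected range 200 nM to 3000 nM).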

Compound 3, half-maximal inhibitory concentration: 36 nM
For compound 3 the middle estimate is 22-fold (1.35 log units) above the measured one; the whole stated range lies above it.
By their numbers in this assay, from the lowest: compound 3; then compound 1; then compound 2.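

In this assay, methyl in place of phenyl on a saturated chain carbon bound to an oxygen gives an 8.6-fold lower number from compound 1 to compound 3 (0.94 log units; beyond the scatter). With the core of compound 1 unchanged, the phenyl of the benzyloxy group is therefore not needed for activity, and the smaller ethoxy group performs better here. The data on hand offer no explanation for this gain.

As far as these compounds go, whether a longer chain such as propyl, or an amine on the ethyl chain, would keep this gain remains open. A single step also cannot show whether the same change would help on another core.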